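Carbamate-to-amide swap on the piperidine nitrogen; efficacy notes

The compounds below may be only part of what the source reports. "The series", "measured", "known", "first", "only" and "open" are said of these compounds alone.

Measured so far:
- compound 1 `Cc1nc(S(C)(=O)=O)ccc1O[C@H]1CC[C@H](OC2CCN(C(=O)OC(C)C)CC2)CC1` — 108%
- compound 2 `C[C@H](CF)OC(=O)N1CCC(O[C@H]2CC[C@H](Oc3cnc(S(C)(=O)=O)cn3)CC2)CC1` — 108%

Both compounds were run in a functional assay on isolated protein for agonist activity at Glucose-dependent insulinotropic receptor (Homo sapiens), read by HTRF and cAMP accumulation; on this read-out lower numbers stand for smaller maximal responses and higher numbers for larger maximal responses. Compound 1 gives 108% and compound 2 gives 108%; the two values are within the scatter of each other, so compound 2 stands level with compound 1 and no order between them can be read. Among the compounds with values here, no step between measured compounds is recorded for this pair, as the two structures differ in more than one place.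

Compound 3 `CS(=O)(=O)c1cnc(O[C@H]2CC[C@H](OC3CCN(C(=O)C4(C(F)(F)F)CCCC4)CC3)CC2)cn1` is not yet measured. Its difference from compound 2 is a group of 9 heavy atoms (6 carbon, 3 fluorine; one five-membered non-aromatic ring of carbon only) in place of a group of 5 heavy atoms (3 carbon, 1 oxygen, 1 fluorine; no ring), on a carbonyl carbon. The change leaves the carbonyl carbon and the ring nitrogen next to it untouched, so the amide-type linkage stays in place while the group hanging from the carbonyl is exchanged.

With both measured compounds reaching a full response, a full or near-full response is expected for compound 3 as well; the step expected from compound 2 to compound 3 is a number 8 percentage points lower from compound 2 to compound 3 (within the scatter), a small decrease that may well lie within the scatter. Compound 3 is estimated at 100%, with a range from 80% to 115%.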

Compound 3, largest response reached (Emax), in percent of the reference or control that the assay uses: 95%
The estimate for compound 3 lay 5 percentage points above the measured number, within the range that was stated.
By their numbers in this assay, from the lowest: compound 3; then compounds 1 and 2 (each within the scatter of the next).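

In this assay, the group of 9 heavy atoms with one five-membered non-aromatic ring of carbon only, in place of the ring-free group of 5 heavy atoms on the carbonyl carbon, gives a number 13 percentage points lower from compound 2 to compound 3 (beyond the scatter). This is the only readable step among the compounds shown, and it indicates that the maximal response is sensitive to the group on this carbonyl carbon, although the change is modest and compound 3 still gives 95%. No accompanying measurement bears on the reason for this step.

The exchange alters the atom count, the ring and the fluorine content at once, and the oxygen of the leaving group goes with it, so the contribution of each part to the step remains unresolved. From the compounds shown here alone, an unsubstituted cyclopentyl group on the same carbonyl carbon would separate the ring from the trifluoromethyl group, while a dimethylamino group there would show how the response behaves with a nitrogen in that place, and both remain open here.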